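Swapping the amide cap on a sulfonamide piperazine

The source may hold more compounds than are shown below. What is called first, only, known or untested is meant among the compounds shown, and "the series" means these compounds.

Three sulfonamides have been measured in an ADME assay on microsomes from liver (Mus musculus) for metabolic stability; a lower number here means slower removal, a higher number faster removal of the compound. Compound 1 `COc1ccc(S(=O)(=O)Nc2ccc(CN3CCN(C(=O)C4CN(C(C)=O)C4)CC3)cc2)cc1` gives 1 mL.min-1.g-1, the lowest of the three numbers. Compound 3 `COc1ccc(S(=O)(=O)Nc2ccc(Cn3cc4c(n3)CN(C(=O)c3cccc(Cl)c3)C4)cc2)cc1` gives 12 mL.min-1.g-1, and compound 2 `Cc1ccc(S(=O)(=O)Nc2ccc(CN[C@@H]3CCN(C(=O)c4cccc(Cl)c4)C3)cc2)cc1` gives 48 mL.min-1.g-1, each of them beyond the scatter from compound 1. Compound 4 `COc1ccc(S(=O)(=O)Nc2ccc(CN3CCN(C(=O)Cn4cccnc4=O)CC3)cc2)cc1` has not yet been measured; it differs from compound 1 in one place: a group of 8 heavy atoms (5 carbon, 2 nitrogen, 1 oxygen; one six-membered aromatic ring with 2 hetero atoms) in place of a group of 7 heavy atoms (5 carbon, 1 nitrogen, 1 oxygen; one four-membered non-aromatic ring with 1 hetero atom), on a carbonyl carbon. Among the measured compounds shown here, no measured pair shows the effect of such an exchange on a carbonyl carbon, so the expectation rests on compound 1 alone. Compound 4 is expected to stay close to compound 1, with the step of a 2.0-fold higher number from compound 1 to compound 4 (0.30 log units; within the scatter) expected to be within or only slightly beyond the scatter, toward faster removal if anything. Compound 4 is estimated at 2 mL.min-1.g-1, in a range from 0.5 mL.min-1.g-1 to 8 mL.min-1.g-1.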

Compound 4, intrinsic clearance in microsomes: < 0.5 mL.min-1.g-1
Compound 4: only a limit was reported; the forecaster's own chance of this, stated with the estimate: 10%; middle value at least 4.0-fold (0.60 log units) from the limit.
By their numbers in this assay, from the lowest: compound 1; then compound 3; then compound 2. At a limit, below all of these: compound 4.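

In this assay, compound 4 gives < 0.5 mL.min-1.g-1, which is a limit of the assay and not a number. Among the compounds shown here, the exchange of 1-acetylazetidin-3-yl for the six-membered aromatic ring on the carbonyl carbon is the first single-place step seen at this position, and it is an at least 2.0-fold lower number from compound 1 to compound 4 (0.30 log units; that floor lies within the scatter), so it shows no move toward faster removal. The true size of the step cannot be read because the reading stops at a limit: the limit of < 0.5 mL.min-1.g-1 in this assay, at which 1 of the 4 values shown sits.

Going by these compounds, whether a plain phenyl ring or a chain carrying an amine on this carbonyl carbon would give similarly low numbers remains open. So does whether this exchange would behave the same way on another core.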